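The source may hold more compounds than are shown below. What is called first, only, known or untested is meant among the compounds shown, and "the series" means these compounds.

Measured compounds:
Compound 1, `O=C(c1ccccc1)N1CCC(NS(=O)(=O)c2cc(S(=O)(=O)c3ccccc3)ccc2C(F)(F)F)CC1`, gives 70 nM in an assay on isolated protein for displacement of a labelled ligand from secreted frizzled-related protein 1 (Homo sapiens), read by fluorescence polarization, with a stated time of 30 min; on this read-out lower numbers stand for stronger inhibition and higher numbers for weaker inhibition.
Compound 2, `CN(C)c1ccc(C(=O)N2CCC(NS(=O)(=O)c3cc(S(=O)(=O)c4ccccc4)ccc3C(F)(F)F)CC2)cc1`, gives 300 nM in this assay.
Compound 3, `CC(C)(C)OC(=O)N1CC[C@H](C(=O)N2CCC(NS(=O)(=O)c3cc(S(=O)(=O)c4ccccc4)ccc3C(F)(F)F)CC2)C1`, gives 70 nM in this assay.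

Compound 3 stands level with compound 1 at the digits shown, the two together the lowest numbers of the three; compound 2 sits apart from them, as the step of a 4.3-fold lower number from compound 2 to compound 3 (0.63 log units; beyond the scatter) shows. The two measured steps at the carbonyl carbon are no change at the digits printed from compound 1 to compound 3 (within the scatter) and a 4.3-fold lower number from compound 2 to compound 3 (0.63 log units; beyond the scatter), while the step at the aromatic carbon, a 4.3-fold higher number from compound 1 to compound 2 (0.63 log units; beyond the scatter), lies elsewhere in the molecule.

Compound 4, `O=C(CC1CCNCC1)N1CCC(NS(=O)(=O)c2cc(S(=O)(=O)c3ccccc3)ccc2C(F)(F)F)CC1`, is not yet measured. Its change from compound 3 is (piperidin-4-yl)methyl in place of 1-(tert-butoxycarbonyl)pyrrolidin-3-yl on a carbonyl carbon. Among the compounds with values here, no measured step covers this exchange: the entering group carries one hydrogen-bond donor, which neither the phenyl of compound 1 nor the group of compound 3 offers, and the tert-butoxycarbonyl leaves. What the data show is that the carbonyl substituent tolerated a large change without a shift in this assay (no change at the digits printed from compound 1 to compound 3 (within the scatter)), whereas the only loss seen came with dimethylamino (a 4.3-fold higher number from compound 1 to compound 2 (0.63 log units; beyond the scatter)). On that basis the expected step of a 2.1-fold higher number from compound 3 to compound 4 (0.33 log units; beyond the scatter) is small, at most modest, and more likely toward a higher number than a lower one. Compound 4 is therefore estimated at 150 nM, with a range from 40 nM to 600 nM in this assay.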

Compound 4, half-maximal inhibitory concentration: 100 nM
Beside the measured number, compound 4's estimate is 1.5-fold (0.18 log units) above it; measured number inside the range.
By their numbers in this assay, from the lowest: compounds 1, 3 and 4 (each within the scatter of the next); then compound 2.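

In this assay, the carbonyl carbon whose other neighbour is an amide-type nitrogen in a ring also accepts (piperidin-4-yl)methyl, a group with a hydrogen-bond donor, with no shift beyond the scatter against either earlier group (a 1.4-fold higher number from compound 3 to compound 4 (0.15 log units; within the scatter); a 1.4-fold higher number from compound 1 to compound 4 (0.15 log units; within the scatter)). Within the data shown here, neither phenyl nor the tert-butoxycarbonyl is therefore required at this carbon to keep the number in this range, and 4-(dimethylamino)phenyl remains the one group in the set that stands apart (a 3.0-fold lower number from compound 2 to compound 4 (0.48 log units; beyond the scatter)). The compounds shown come with no evidence that accounts for this flat response.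

Still open, going by these compounds, is whether the ring nitrogen of the piperidine plays any part: a cyclohexylmethyl group, or the same piperidine capped as an acetamide, would separate that nitrogen from the ring around it. Also open, on these data alone, are a carboxylic acid on this substituent, a longer chain between the carbonyl and the ring, and whether a methoxy group on the phenyl of compound 1 would give a step like the one seen with dimethylamino.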